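Methoxy added beside the acrylonitrile of compound 2

The source may hold more compounds than are shown below. What is called first, only, known or untested is meant among the compounds shown, and "the series" means these compounds.

Compound 1 `N#C/C(=C\c1ccc(Br)cc1)C(=O)O` gives 500 nM in an assay on RBE4 cells for inhibition of Monocarboxylate transporter 1 (Rattus norvegicus), with a stated time of 15 min; on this read-out lower numbers stand for stronger inhibition and higher numbers for weaker inhibition.
Compound 2 `CCCN(CCC)c1ccc(/C=C(\C#N)C(=O)O)cc1` gives 10 nM in this assay.
Compound 3 `N#C/C(=C\c1ccc(N2CCCCC2)cc1)C(=O)O` gives 140 nM in this assay.

Among these three numbers compound 2 stands lowest in this assay; its nearest neighbour is compound 3, and compound 1 lies furthest away. For the measured compounds named here, the one single-point step that has been measured, piperidin-1-yl in place of bromo on an aromatic carbon, gave a 3.6-fold lower number from compound 1 to compound 3 (0.55 log units; beyond the scatter). Compound 4 `CCCN(CCC)c1ccc(/C=C(\C#N)C(=O)O)c(OC)c1` is not yet measured. It differs from compound 2 in one place: methoxy in place of hydrogen on an aromatic carbon. Going by the values given here, no measured step touches this position or this group, so the measured change from compound 1 to compound 3 does not bear on it directly; it only shows that the core of compound 2 tolerates substitution on the ring without loss. With no evidence for a shift either way, the number for compound 4 is expected to stay close to that of compound 2, and the step from compound 2 to compound 4 is estimated as a 1.5-fold higher number from compound 2 to compound 4 (0.18 log units; within the scatter). Compound 4 is therefore expected to give about 15 nM, within a range from 4 nM to 60 nM.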

Compound 4, half-maximal inhibitory concentration: 12 nM
For compound 4 the middle estimate is 1.3-fold (0.10 log units) above the measured one; the measured number falls inside the stated range.
By their numbers in this assay, from the lowest: compounds 2 and 4 (each within the scatter of the next); then compound 3; then compound 1.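

In this assay, placing methoxy in place of hydrogen ortho to the 2-carboxy-2-cyanoethenyl group and meta to the dipropylamino group gives a 1.2-fold higher number from compound 2 to compound 4 (0.08 log units; within the scatter), a step within the usual scatter. For the compounds shown here, this is the only measured change at this position, and it shows that, with the dipropylamino group in place, this position accepts methoxy with no change beyond the scatter. No measured evidence accounts for this result.

Going by these compounds, whether hydroxy, ethoxy or fluoro at this position would behave as methoxy does remains open. On these data alone, it is also open whether methoxy at the same place would give a similar result in compound 3, with its piperidin-1-yl group, or in compound 1, with its bromo group.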